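The source may hold more compounds than are shown below. What is called first, only, known or untested is meant among the compounds shown, and "the series" means these compounds.

Compound 1 `COc1cc(OCc2ccnc(Nc3ccn(C)n3)n2)cc2sc(N[C@H]3CCCC[C@@H]3O)nc12`: 46.2 mL/min/kg
Compound 2 `COc1cc(OCc2ccnc(Nc3cn[nH]c3)n2)cc2sc(N[C@H]3CCCC[C@@H]3O)nc12`: 120 mL/min/kg

In an ADME assay on microsomes from liver (Rattus norvegicus, strain Sprague-Dawley) for pharmacokinetics, read by LC-MS, using NADPH, with a stated time of 45 min, tested at 1 uM (a higher number here means faster removal of the compound, a lower number slower removal), compound 2 stands higher of the two, at 120 mL/min/kg. Compound 3 `COc1cc(OCc2ccnc(Nc3cnoc3)n2)cc2sc(N[C@H]3CCCC[C@@H]3O)nc12` carries 1,2-oxazol-4-yl in place of 1H-pyrazol-4-yl on a nitrogen on an aromatic ring. Among the compounds with values here, one measured step bears on this, at the same place, where 1H-pyrazol-4-yl entered: a 2.6-fold higher number from compound 1 to compound 2 (0.41 log units; beyond the scatter). That single step is modest, so only a small move towards a lower number is expected in this assay, probably not beyond the scatter. The expected step is a 1.5-fold lower number from compound 2 to compound 3 (0.18 log units; within the scatter). The estimate for compound 3 is 80 mL/min/kg, with an expected range of 38 mL/min/kg to 165 mL/min/kg.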

Compound 3, clearance: 87 mL/min/kg
The estimate for compound 3 lay 1.1-fold (0.04 log units) below the measured number; measured number inside the range.
By their numbers in this assay, from the lowest: compounds 1, 3 and 2 (each within the scatter of the next, the first and the last beyond it).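

In this assay, 1,2-oxazol-4-yl on this nitrogen gives a 1.4-fold lower number from compound 2 to compound 3 (0.14 log units; within the scatter) and a 1.9-fold higher number from compound 1 to compound 3 (0.27 log units; within the scatter), so compound 3 lies within the scatter of both neighbours. Losing the hydrogen-bond donor of 1H-pyrazol-4-yl therefore gives no step beyond the scatter at this place. No measurement shown gives a reason for these numbers.

Still open is what lies behind a 2.6-fold higher number from compound 1 to compound 2 (0.41 log units; beyond the scatter): compound 1 and compound 2 differ both in the methyl and in the pyrazole attachment. 1-Methyl-1H-pyrazol-4-yl on this nitrogen would separate the two.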